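Swapping Isobutyl for Cyclobutyl on an Amide Carbonyl

A few compounds are considered here, and "the series" means these few. Any claim that something is new, unique, unknown or untested is made for them only; others in the source may bear on it.

Three compounds have been measured in a functional assay on RKE cells for antagonist activity at Vasoactive intestinal polypeptide receptor 1 (Rattus norvegicus), read by HTRF and cAMP accumulation, with stated times of 10 min and 30 min; a higher number here means a weaker inhibitor, a lower number a stronger inhibitor:

compound 1 `COc1cccc(-c2cc(C(C)(C)C)cc(C(C)C)c2CO)c1`: 200 nM
compound 2 `CC(C)c1cc(C(C)(C)C)cc(-c2cccc3ccccc23)c1CO`: 180 nM
compound 3 `CC(C)CC(=O)Nc1sc2c(c1C#N)CCCC2`: 1900 nM

Compound 1 and compound 2 share one core and give numbers that sit within the scatter of each other, so no order between them can be read. Compound 3 is built on a different core and gives the highest number of the three; the gaps to compound 1 and to compound 2 both lie beyond the scatter, so in this assay compound 3 is the weakest inhibitor shown.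

Compound 4 `N#Cc1c(NC(=O)C2CCC2)sc2c1CCCC2` keeps the core of compound 3 and differs from it in one place: cyclobutyl in place of isobutyl on a carbonyl carbon. Among the compounds with values here, both groups are of the same size, neither carries a donor or an acceptor, and the only change is that an open chain is closed into a ring. Within the data shown here, no measured pair in this set shows what such a closure does.

The expected step is therefore small, a 1.1-fold lower number from compound 3 to compound 4 (0.05 log units; within the scatter), in no firm direction and most likely within the scatter. Compound 4 is expected to give about 1700 nM, with a range from 600 nM to 5000 nM.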

Compound 4, half-maximal inhibitory concentration: 1800 nM
Compound 4: middle estimate off by 1.1-fold (0.02 log units), on the low side, within the range that was stated.
By their numbers in this assay, from the lowest: compounds 2 and 1 (each within the scatter of the next); then compounds 4 and 3 (each within the scatter of the next).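

Closing the isobutyl into a cyclobutyl on a carbonyl carbon gives the first one-place comparison in this set, and in this assay it comes to a 1.1-fold lower number from compound 3 to compound 4 (0.02 log units; within the scatter) for this swap. At this place, an open chain and a four-membered non-aromatic ring of carbon only cannot be told apart by their numbers, with the heavy-atom count held the same and no hydrogen-bond donor or acceptor on either group, so this single step shows that the ring closure alone has no readable effect here. Nothing available accounts for why the two groups read alike.

Both groups are plain carbon groups, so the compounds shown leave open whether an amine, a carboxylic acid or a longer chain such as n-hexyl on this carbonyl carbon would move the number beyond the scatter. Within the data shown here, they also leave open whether a larger ring such as cyclohexyl, or a phenyl, would read like cyclobutyl and isobutyl, so the tolerance of this place is known for only this one pair.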